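From ester to alcohol on the amide side chain

The source may hold more compounds than are shown below. What is called first, only, known or untested is meant among the compounds shown, and "the series" means these compounds.

In a functional assay on Caco-2 cells (Homo sapiens) for antiproliferative activity, read by MTT assay, with a stated time of 48 h (a higher number here means a weaker inhibitor, a lower number a stronger inhibitor), compound 1 (`CCn1c(C(=O)NCCCN(C)C)ccc1C(CC)(CC)c1ccc(OCCC(O)(CC)CC)c(C)c1`) gives 490 nM as its reading. Compound 2 (`CCC(C)C(NC(=O)c1ccc(C(CC)(CC)c2ccc(OCCC(O)(CC)CC)c(C)c2)n1CC)C(=O)OC`) gives > 50000 nM as its reading, which is a limit of the assay and not a number. For the measured compounds named here, compound 2 therefore has no exact position and stands at the limit of > 50000 nM in this assay, at which 1 of the 2 values shown sits, on the numbers so far.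

Compound 3 (`CCC(C)C(CO)NC(=O)c1ccc(C(CC)(CC)c2ccc(OCCC(O)(CC)CC)c(C)c2)n1CC`) differs from compound 2 in one place (hydroxymethyl in place of methoxycarbonyl on a saturated chain carbon bound to an amide-type nitrogen and a saturated chain carbon) and keeps everything else. Going by the values given here, the only measured step (an at least 100-fold higher number from compound 1 to compound 2 (2.00 log units; beyond the scatter)) was large and beyond the scatter, but it replaced the whole group on the amide-type nitrogen, whereas this swap changes only part of that group. A smaller move towards a lower number is therefore expected in this assay, and a second limit reading remains possible. The expected step is (an at least 3.3-fold lower number from compound 2 to compound 3 (0.52 log units; beyond the scatter)) on this estimate. For compound 3 the estimated value is 15000 nM with 2000 nM to 50000 nM as its expected range.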

Compound 3, half-maximal inhibitory concentration: > 50000 nM
Compound 3: no number, only a limit; the forecaster's own chance of this, stated with the estimate: 40%; middle value at least 3.3-fold (0.52 log units) from the limit.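

In this assay compound 3 gives > 50000 nM, which is a limit of the assay and not a number, so the hydroxymethyl group on this saturated chain carbon does not bring the reading inside the measurable range. The step between compound 2 and compound 3 cannot be read, because both readings are limits: the limit of > 50000 nM in this assay, at which 2 of the 3 values shown sit.

With 1-(hydroxymethyl)-2-methylbutyl in place of 3-(dimethylamino)propyl on the amide-type nitrogen, the change is an at least 100-fold higher number from compound 1 to compound 3 (2.00 log units; beyond the scatter), so a second branched side chain also ends far from compound 1.

Still open, going by these compounds, is which part of the side chain counts, since each of these swaps changes the dimethylamino group and the chain shape together. A carboxylic acid on this carbon, or a branched chain ending in an amine, could help separate the two.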